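The source may hold more compounds than are shown below. What is called first, only, known or untested is meant among the compounds shown, and "the series" means these compounds.

Measured so far in a functional assay on K562 cells (Homo sapiens) for cytotoxicity, read by sulforhodamine B assay, with a stated time of 48 h; a higher number here means a weaker inhibitor of growth, a lower number a stronger inhibitor of growth:
- compound 1 `Cc1c(NC(=O)COc2ccc(/C=C3\SC(=O)NC3=O)cc2)c(=O)n(-c2ccccc2)n1C` gives < 100000 nM, a limit of the assay rather than a number.
- compound 2 `O=C(COc1ccc(/C=C2\SC(=O)NC2=O)cc1)Nc1nc2ccccc2s1` gives < 100000 nM, again a limit of the assay.
- compound 3 `O=C1NC(=O)/C(=C\c2ccc(OCC(=O)N3C(=O)c4ccccc4S3(=O)=O)cc2)S1` gives < 100000 nM, also a limit of the assay.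

Compound 2 therefore stands at the limit of < 100000 nM in this assay, at which 3 of the 3 values shown sit; no numerical position within the series can be given for it, and the same holds for compound 1 and compound 3. Going by the values given here, no pair of measured compounds differs in one place only, so no measured step is available.

Compound 4 `O=C(COc1ccc(/C=C2\SC(=O)NC2=O)cc1)Nc1ccccn1` has not yet been measured. It differs from compound 2 by pyridin-2-yl in place of 1,3-benzothiazol-2-yl on an amide-type nitrogen. Among the compounds with values here, with every value so far resting on the same limit, there is no measured step on which to size the change; the expectation is that compound 4 will likewise come out at or near the limit, with any shift from compound 2 to compound 4 not clearly beyond the scatter. The estimated step is a step that the limit leaves unreadable from compound 2 to compound 4. Compound 4 is expected to give about 70000 nM in this assay, within 20000 nM to 150000 nM, with a substantial chance that only a limit is reported.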

Compound 4, concentration for total growth inhibition: < 100000 nM
Compound 4: no number, only a limit; the forecaster's own chance of this, stated with the estimate: 70%; the middle value is on the limit's open side.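

No step can be read from compound 2 to compound 4 in this assay, since both values are limits and not numbers: the limit of < 100000 nM in this assay, at which 4 of the 4 values shown sit.

The compounds shown leave open whether pyridin-2-yl in place of 1,3-benzothiazol-2-yl on the amide-type nitrogen changes growth inhibition at all, and where any of the four compounds stands numerically.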